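Thioether series: cytotoxicity working notes

The compounds below may be only part of what the source reports. "The series", "measured", "known", "first", "only" and "open" are said of these compounds alone.

Compound 1 `O=c1cc(CSc2nc3ccccc3s2)oc2ccc(Cl)cc12` was run in a functional assay on HEp-2 cells (Homo sapiens) for cytotoxicity, read by MTT assay, with a stated time of 72 h; on this read-out lower numbers stand for stronger inhibition and higher numbers for weaker inhibition. In this assay compound 1 reaches only the limit > 25000 nM. Compound 2 `Cc1ccc2oc(CSc3nc4ccccc4s3)cc(=O)c2c1` also gives in this assay only the limit > 25000 nM. Compound 3 `Cc1ccc2oc(CSc3nnc(C)s3)cc(=O)c2c1` has a core that differs from that of compound 2 in a way not broken down here. In this assay compound 3 likewise gives only the limit > 25000 nM. The change from compound 2 to compound 1, (chloro in place of methyl on an aromatic carbon), produces a step that the two limits leave unreadable from compound 2 to compound 1, and its size cannot be read because of the limit of > 25000 nM in this assay, at which 3 of the 3 values shown sit. Compound 4 `Cc1nnc(SCc2cc(=O)c3cc(Cl)ccc3o2)s1` carries the same change relative to compound 3, (chloro in place of methyl on an aromatic carbon), at a place described in the same words as for compound 1. Because (the limit of > 25000 nM in this assay, at which 3 of the 3 values shown sit), the step from compound 3 to compound 4 is expected to be a step that the limit leaves unreadable from compound 3 to compound 4. For compound 4 in this assay an inhibitory concentration of about 40000 nM is estimated, with a range from 15000 nM to 150000 nM, and the result is expected most often to be reported only as a limit.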

Compound 4, half-maximal inhibitory concentration: > 25000 nM
Compound 4: no number, only a limit; the forecaster's own chance of this, stated with the estimate: 80%; the middle value lies beyond the limit too.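

No new step can be read for compound 3 and compound 4 in this assay, and the step between them stays unreadable because both are limits and not numbers: the limit of > 25000 nM in this assay, at which 4 of the 4 values shown sit.

The compounds shown leave open whether chloro in place of methyl, or the difference between the cores of compound 2 and compound 3, changes cytotoxicity at all.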